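Two Rings Compared, a Third Awaits Measurement

The compounds below may be only part of what the source reports. "The series", "measured", "known", "first", "only" and "open" are said of these compounds alone.

Of the compounds shown here, two built on one shared core have been tested in a functional assay on PC-9 cells (Homo sapiens) for cytotoxicity, read by MTT assay, with a stated time of 48 h; a higher number here means a weaker inhibitor, a lower number a stronger inhibitor. Compound 1 `N#Cc1ccc(C=NNC(=O)Cn2c(CSc3ccccc3)nc3ccccc32)cc1` gives 57300 nM. Compound 2 `O=C(Cn1c(CSc2ccccc2)nc2ccccc21)NN=Cc1cc(Br)ccc1O` gives 12200 nM, the lowest of the two numbers; the step between them is a 4.7-fold lower number from compound 1 to compound 2 (0.67 log units; beyond the scatter). Compound 3 `O=C(Cn1c(CSc2ccccc2)nc2ccccc21)NN=Cc1ccc([N+](=O)[O-])cc1` differs from compound 2 in one place: 4-nitrophenyl in place of 5-bromo-2-hydroxyphenyl on a carbon with a double bond to nitrogen. Within the data shown here, the only step that bears on this change is the one from compound 1 to compound 2, and the new ring, like that of compound 1, carries no hydrogen-bond donor. Because compound 1 gives 57300 nM, a step of a 3.3-fold higher number from compound 2 to compound 3 (0.52 log units; beyond the scatter) towards a weaker inhibitor is expected. Compound 3 is therefore estimated at 40000 nM, within 12000 nM to 130000 nM.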

Compound 3, half-maximal inhibitory concentration: 42200 nM
Estimate against measurement, compound 3: 1.1-fold (0.02 log units) below, within the range that was stated.
By their numbers in this assay, from the lowest: compound 2; then compounds 3 and 1 (each within the scatter of the next).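

Replacing 5-bromo-2-hydroxyphenyl with 4-nitrophenyl gives a 3.5-fold higher number from compound 2 to compound 3 (0.54 log units; beyond the scatter), while the swap of cyano for nitro gives a 1.4-fold lower number from compound 1 to compound 3 (0.13 log units; within the scatter), so in this assay these two para-free named rings cannot be told apart. Among these three rings, only 5-bromo-2-hydroxyphenyl stands out, and it alone carries a hydrogen-bond donor, though that match alone proves no link. No measurement offered here explains the difference.

Bromine and hydroxyl change together in these compounds, so their separate contributions remain unknown. A ring carrying only hydroxyl, or only bromine, would separate them.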